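Ring Size Change on a Shared Core: Stability Outlook

The source may report more compounds than this note shows. Statements on the series, on what has been measured and on what is new or still open speak of the compounds shown alone.

Measured so far:
compound 1 `CC(=O)N[C@@H]1CCC[C@H](C(=O)Nc2cc(-c3cnn4c3CCCCC4)c(Cl)cn2)C1` — 4.6 uL/min
compound 2 `CC(=O)N[C@@H]1CCC[C@H](C(=O)Nc2cc(-c3cnn4c3CC(C)(C)CC4)ccn2)C1` — 4.3 uL/min

In an ADME assay on cells (Hepatocyte, Homo sapiens) for metabolic stability, using equilibrium dialysis (a higher number here means faster removal of the compound, a lower number slower removal), compound 1 gives 4.6 uL/min and compound 2 gives 4.3 uL/min. The two numbers lie within the usual scatter of each other, so compound 1 stands alongside compound 2 rather than apart from it.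

Compound 3 `CC(=O)N[C@@H]1CCC[C@H](C(=O)Nc2cc(-c3cnn4c3CC(C)(C)C4)c(Cl)cn2)C1` is not yet measured. It differs from compound 1 by a group of 10 heavy atoms (8 carbon, 2 nitrogen; one five-membered non-aromatic ring with 1 hetero atom, one five-membered aromatic ring with 2 hetero atoms) in place of a group of 10 heavy atoms (8 carbon, 2 nitrogen; one five-membered aromatic ring with 2 hetero atoms, one seven-membered non-aromatic ring with 1 hetero atom), on an aromatic carbon. Within the data shown here, no measured pair shows a change of this kind, so nothing here sets its size. For compound 3 a step within the scatter, in no clear direction, is expected: a 1.0-fold lower number from compound 1 to compound 3 (0.01 log units; within the scatter). Compound 3 is therefore estimated at 4.5 uL/min, with a range from 2.2 uL/min to 9 uL/min.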

Compound 3, intrinsic clearance in a liver preparation (reported as CLH), per the amount of preparation that the assay uses: 3.5 uL/min
Compound 3: middle estimate off by 1.3-fold (0.11 log units), on the high side, and the stated range covers the measured number.
By their numbers in this assay, from the lowest: compounds 3, 2 and 1 (each within the scatter of the next).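

In this assay, putting a five-membered non-aromatic ring in place of the seven-membered non-aromatic ring, on the aromatic carbon ortho to the chloro group, gives a 1.3-fold lower number from compound 1 to compound 3 (0.12 log units; within the scatter). This position therefore tolerates this change of ring size without a step beyond the scatter. No measurement here offers an explanation for this result.

Still open, as far as these compounds go, is whether an amine or a carboxylic acid on this ring would also stay within the scatter. Among these compounds, the effect of the chloro group alone also remains unread, since no pair differs only there.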